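Selenocyanate side chain exchange on the shared core

The compounds below may be only part of what the source reports. "The series", "measured", "known", "first", "only" and "open" are said of these compounds alone.

Measured:
compound 1 `COc1ccc(N(C)c2nc(C)nc3ccccc23)cc1C(=O)OCCC[Se]C#N` — 720 nM
compound 2 `C[Se]c1ccc(N(C)c2nc(C)nc3ccccc23)cc1C` — 3 nM

In a functional assay on HCT-116 cells (Homo sapiens) for inhibition, read by MTT assay, with a stated time of 48 h (on this read-out lower numbers stand for stronger inhibition and higher numbers for weaker inhibition), compound 1 gives 720 nM, the higher of the two numbers; compound 2 gives 3 nM, a difference well beyond the scatter. Compound 3 `COc1ccc(N(C)c2nc(C)nc3ccccc23)cc1OCC[Se]C#N` is not yet measured. It differs from compound 1 as follows: a group of 6 heavy atoms (3 carbon, 1 nitrogen, 1 oxygen, 1 selenium; no ring) in place of a group of 9 heavy atoms (5 carbon, 1 nitrogen, 2 oxygen, 1 selenium; no ring), on an aromatic carbon, the place being an aromatic carbon ortho to a methoxy group and meta to a large group. Within the data shown here, no step of this kind has been measured in this assay, so the step of a 1.4-fold lower number from compound 1 to compound 3 (0.16 log units; within the scatter) is expected to be small, at most near the edge of the scatter. Compound 3 is therefore estimated at 500 nM, with a range of 150 nM to 2000 nM.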

Compound 3, half-maximal inhibitory concentration: 18 nM
The estimate for compound 3 lay 28-fold (1.44 log units) above the measured number; the whole stated range lies above it.
By their numbers in this assay, from the lowest: compound 2; then compound 3; then compound 1.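

In this assay, this aromatic carbon, ortho to a methoxy group and meta to a large group, proves sensitive to the side chain it carries: a 40-fold lower number from compound 1 to compound 3 (1.60 log units; beyond the scatter) is a large step. The selenocyanate end is present in both compounds, so its presence alone does not fix the number.

On these data alone, the carbonyl and the chain length change together in this one step, and their shares stay open; an ether-linked longer chain, or an amine in place of the selenocyanate, would test this further. No available measurement accounts for the step.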